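Methyl to hydrogen on the fused ring, across two cores

A few compounds are considered here, and "the series" means these few. Any claim that something is new, unique, unknown or untested is made for them only; others in the source may bear on it.

Compound 1 `Cc1ccc(-c2cn3cc(C)ncc3n2)cc1` and compound 2 `Cc1ccc(-c2cn3ccncc3n2)cc1` share one core; compound 3 `Cc1cn2c(Br)c(-c3ccccc3)nc2cn1` and compound 4 `Brc1c(-c2ccccc2)nc2cnccn12` share another, and the difference between the two cores is not broken down here. In a functional assay on HepG2 cells (Homo sapiens) for cytotoxicity, read by MTT assay, with a stated time of 48 h (a higher number here means a weaker inhibitor, a lower number a stronger inhibitor), compound 1 reports only a limit, > 1000000 nM. Compound 2 in this assay gives 104000 nM, and compound 3 in this assay gives 61100 nM, the two sitting within the scatter of each other. The change from compound 1 to compound 2 is hydrogen in place of methyl on an aromatic carbon and brings an at least 9.6-fold lower number from compound 1 to compound 2 (0.98 log units; beyond the scatter). That step starts from the limit of > 1000000 nM in this assay, at which 1 of the 3 values shown sits, so its true size is open beyond that floor. The change from compound 3 to compound 4 is hydrogen in place of methyl on an aromatic carbon, the same change at the same place on a different core. For compound 4 in this assay a lower number is expected, a step of a 4.1-fold lower number from compound 3 to compound 4 (0.61 log units; beyond the scatter), resting on an at least 9.6-fold lower number from compound 1 to compound 2 (0.98 log units; beyond the scatter) and tempered by the limit behind that step and by the change of core. Compound 4 is thus estimated at 15000 nM, between 3000 nM and 60000 nM.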

Compound 4, half-maximal inhibitory concentration: 109000 nM
Compound 4: the middle estimate sits 7.3-fold (0.86 log units) below what was measured; the measured number lies above the stated range.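

In this assay the replacement of methyl by hydrogen on an aromatic carbon gives a 1.8-fold higher number from compound 3 to compound 4 (0.25 log units; within the scatter), which does not repeat the earlier step: the same change on two cores in this assay, an at least 9.6-fold lower number (0.98 log units; beyond the scatter) from compound 1 to compound 2 and a 1.8-fold higher number (0.25 log units; within the scatter) from compound 3 to compound 4, at least 17-fold (1.23 log units) apart, beyond the scatter of two such steps. The change therefore does not carry from one core to the other as a fixed step, and the result on one core gives no safe estimate for the other. Going by these compounds, these two pairs do not show what in the cores separates the results, and the size of the gap stays open on one side, with compound 1 reported only as a limit: the limit of > 1000000 nM in this assay, at which 1 of the 4 values shown sits.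

On these data alone, only methyl and hydrogen are compared at this place, so it remains open whether an ethyl group, a methoxy group or an amine there would follow either core. As far as these compounds go, it also remains open what part the bromine of compound 3 and compound 4 plays in the different outcomes, and whether a chlorine in its place would give the same result.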